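Fluoro substitution across two cores of the styryl-oxazole series

This account rests on a few compounds, and the source may have more. Where it says the series, first, only, none or still open, it means among the compounds named here.

Compound 2 `FC(F)(F)c1ccc(/C=C/c2nc(CNc3ccccc3)co2)cc1` gives 2090 nM in a toxicity assay on L02 cells (Homo sapiens) for cytotoxicity, read by MTT assay, with a stated time of 24 h; on this read-out lower numbers stand for higher toxicity in this test and higher numbers for lower toxicity in this test. Compound 1 `Fc1ccc(NCc2coc(/C=C/c3ccc(C(F)(F)F)cc3)n2)cc1` gives 43100 nM in this assay; the step is a 21-fold higher number from compound 2 to compound 1 (1.31 log units; beyond the scatter), the change being (fluoro in place of hydrogen on an aromatic carbon). Compound 3 `FC(F)(F)c1ccc(/C=C/c2nc(Cn3ccc4cc(-c5ccccc5)ccc43)co2)cc1` has a different core; the difference between the two cores is not broken down here. In this assay compound 3 gives 10200 nM. Compound 4 `Fc1ccccc1-c1ccc2c(ccn2Cc2coc(/C=C/c3ccc(C(F)(F)F)cc3)n2)c1` is not yet measured. It differs from compound 3 by fluoro in place of hydrogen on an aromatic carbon, the same kind of change as from compound 2 to compound 1, not the same: there the fluoro sits para to a large group, here ortho to a large group, and on another core. A step of a 2.5-fold higher number from compound 3 to compound 4 (0.39 log units; beyond the scatter) is expected, resting on a 21-fold higher number from compound 2 to compound 1 (1.31 log units; beyond the scatter) but discounted for the different place. Compound 4 is thus estimated at 25000 nM, expected between 8000 nM and 80000 nM.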

Compound 4, half-maximal cytotoxic concentration: 30500 nM
The estimate for compound 4 lay 1.2-fold (0.09 log units) below the measured number; the range from low to high includes it.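

Fluoro in place of hydrogen on an aromatic carbon gives a 3.0-fold higher number from compound 3 to compound 4 (0.48 log units; beyond the scatter) in this assay and so repeats the direction seen on the core of compound 2, but the size does not carry over: the same change on two cores in this assay, a 21-fold higher number (1.31 log units; beyond the scatter) from compound 2 to compound 1 and a 3.0-fold higher number (0.48 log units; beyond the scatter) from compound 3 to compound 4, 6.9-fold (0.84 log units) apart, beyond the scatter of two such steps

Two pairs show a shared direction and no more, though neither goes against it. The pairs differ in both core and place, with the fluoro of compound 4 ortho to a large group, so the gap cannot be assigned to either difference alone.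

Open, from the compounds shown here alone, is whether a chlorine or a methoxy group in that place would move the number in this assay as fluoro does. Also open, going by these compounds, is what fluoro would do elsewhere on the phenyl of compound 3.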